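From ethylsulfanyl to benzylsulfanyl at the assay limit

This account rests on a few compounds, and the source may have more. Where it says the series, first, only, none or still open, it means among the compounds named here.

Measured so far in a functional assay on HCT-116 cells (Homo sapiens) for inhibition, read by MTT assay, with a stated time of 48 h (on this read-out lower numbers stand for stronger inhibition and higher numbers for weaker inhibition), with each value a limit of the assay and not a number:
- Compound 1 `COc1cc(-c2nnc(SC)n2-c2ccc(N(C)C)cc2)cc(OC)c1OC` gives > 60000 nM as a limit
- Compound 2 `CCSc1nnc(-c2cc(OC)c(OC)c(OC)c2)n1-c1ccc(N(C)C)cc1` gives > 60000 nM as a limit

Compound 2 has no exact value and stands only at its limit of > 60000 nM on this read-out. The evidence so far amounts to the limit of > 60000 nM in this assay, at which 2 of the 2 values shown sit, and nothing more.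

Compound 3 `COc1cc(-c2nnc(SCc3ccccc3)n2-c2ccc(N(C)C)cc2)cc(OC)c1OC` has not yet been measured. It differs from compound 2 by phenyl in place of methyl on a saturated chain carbon bound to a sulfur with phenyl in place of methyl on a saturated chain carbon bound to a sulfur, so ethylsulfanyl becomes benzylsulfanyl.

Among the compounds with values here, the only measured step that bears on this change is a step that the two limits leave unreadable from compound 1 to compound 2 and it offers no size to carry over. The expectation is therefore loose, and compound 3 may also be reported only as a limit. The step expected in this assay is an at least 1.5-fold lower number from compound 2 to compound 3 (0.17 log units; that floor lies within the scatter) and it is estimated to be modest, towards stronger inhibition if any change shows. Compound 3 is estimated at 40000 nM with an expected range from 10000 nM to 60000 nM on this read-out.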

Compound 3, half-maximal inhibitory concentration: 54000 nM
Beside the measured number, compound 3's estimate is 1.4-fold (0.13 log units) below it, within the range that was stated.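

In this assay, within the data shown here, compound 3 gives 54000 nM, the first exact number at this position. Among these compounds, the two smaller sulfur substituents of the earlier compounds left only limits and a step between them that cannot be read. Phenyl in place of methyl on a saturated chain carbon bound to a sulfur gives an at least 1.1-fold lower number from compound 2 to compound 3 (0.04 log units; that floor lies within the scatter), and phenyl in place of hydrogen at that carbon gives an at least 1.1-fold lower number from compound 1 to compound 3 (0.04 log units; that floor lies within the scatter). Both floors lie within the scatter, so ethylsulfanyl to benzylsulfanyl yields a readable number without establishing a real gain in inhibition, and the data still rest largely on: the limit of > 60000 nM in this assay, at which 2 of the 3 values shown sit.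

The compounds shown leave open whether a cyclohexylmethyl group on the sulfur would give a number like that of compound 3, which would separate the aromatic ring from the size of the substituent. They also leave open whether a phenethyl chain, or a benzyl group carrying an amine or a carboxylic acid, would move the number beyond the scatter.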